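Aryl urea swap on a shared thienopyrimidine-linked scaffold

The source may hold more compounds than are shown below. What is called first, only, known or untested is meant among the compounds shown, and "the series" means these compounds.

Measured compounds and their values:
Compound 1 `Cc1cccc(NC(=O)Nc2nnc(Sc3ncnc4scc(-c5ccncc5)c34)s2)c1` — 12200 nM
Compound 2 `O=C(Nc1cccc(C(F)(F)F)c1)Nc1nnc(Sc2ncnc3scc(-c4ccncc4)c23)s1` — 22400 nM
Compound 3 `Cc1ccc(NC(=O)Nc2nnc(Sc3ncnc4scc(-c5ccncc5)c34)s2)cc1Cl` — 23200 nM

The three compounds share one core and differ only in the aryl group on the urea nitrogen. In a functional assay on HUVEC cells (Homo sapiens) for antiproliferative activity, read by MTT assay, with a stated time of 48 h (a higher number here means a weaker inhibitor, a lower number a stronger inhibitor), compound 2 gives 22400 nM, a number that lies within the scatter of both compound 1 and compound 3, so the three cannot be told apart on these data.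

Compound 4 `O=C(Nc1ccc(F)cc1)Nc1nnc(Sc2ncnc3scc(-c4ccncc4)c23)s1` has not yet been measured. It arises from compound 2 by the change (4-fluorophenyl in place of 3-(trifluoromethyl)phenyl on an amide-type nitrogen). Within the data shown here, two measured steps bear on it: a 1.8-fold higher number from compound 1 to compound 2 (0.26 log units; within the scatter), and a 1.0-fold higher number from compound 2 to compound 3 (0.02 log units; within the scatter). Both alter the aryl group on the same nitrogen, and neither moves the number beyond the scatter. A third step, a 1.9-fold higher number from compound 1 to compound 3 (0.28 log units; within the scatter), also stays within the scatter.

Since every aryl swap seen so far on this nitrogen has left this assay essentially unchanged, no step beyond the scatter is expected for compound 4 either, in either direction. The expected step is a 1.2-fold lower number from compound 2 to compound 4 (0.09 log units; within the scatter). Compound 4 is therefore estimated at 18000 nM, with a range from 7000 nM to 45000 nM.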

Compound 4, half-maximal inhibitory concentration: 28300 nM
Estimate against measurement, compound 4: 1.6-fold (0.20 log units) below; low and high end bracket the measured number.
By their numbers in this assay, from the lowest: compounds 1, 2, 3 and 4 (each within the scatter of the next, the first and the last beyond it).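

In this assay, among these compounds, the change to 4-fluorophenyl on this amide-type nitrogen gives a 1.3-fold higher number from compound 2 to compound 4 (0.10 log units; within the scatter) and a 1.2-fold higher number from compound 3 to compound 4 (0.09 log units; within the scatter), yet it also gives a 2.3-fold higher number from compound 1 to compound 4 (0.37 log units; beyond the scatter), the first step to pass the scatter, though only modestly. The aryl group on this nitrogen is therefore not entirely without consequence: 3-methylphenyl and 4-fluorophenyl can be told apart here, even though each stays within the scatter of both 3-(trifluoromethyl)phenyl and 3-chloro-4-methylphenyl. No measurement is available that would explain this one separation.

All four compounds carry a substituted phenyl ring on this nitrogen, so the compounds shown leave open what a phenyl ring bearing an amine or a carboxylic acid would do. They also leave open whether replacing the phenyl ring with a plain butyl chain would move the number further than this modest step, or whether it, too, would stay within the scatter of most of the series.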